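Cytotoxicity notes: aryl substituent swap in the nitroimidazole-oxazine series

A few compounds are considered here, and "the series" means these few. Any claim that something is new, unique, unknown or untested is made for them only; others in the source may bear on it.

Compound 1 `O=[N+]([O-])c1cn2c(n1)OC(CNc1ccc(OC(F)(F)F)cc1)CC2` is recorded in an ADME assay on MRC5 cells (Homo sapiens) for cytotoxicity, read by resazurin assay, with a stated time of 72 h; a higher number here means a weaker inhibitor, a lower number a stronger inhibitor. In this assay compound 1 gives only the limit >= 40000 nM. Compound 2 `CC1(CNc2ccc(OC(F)(F)F)cc2)CCn2cc([N+](=O)[O-])nc2O1` carries a methyl in place of hydrogen on a saturated ring carbon; in this assay compound 2 also gives only the limit >= 40000 nM. The step that the two limits leave unreadable from compound 1 to compound 2 is therefore unreadable, both values sitting at the same limit (the limit of >= 40000 nM in this assay, at which 2 of the 2 values shown sit). Compound 3 `CC1(CNc2ccc(Cl)cc2)CCn2cc([N+](=O)[O-])nc2O1` differs from compound 2 by chloro in place of trifluoromethoxy on an aromatic carbon. Going by the values given here, no measured step bears on this change, so no shift beyond the scatter is expected; the expected step is a step that the limit leaves unreadable from compound 2 to compound 3. Compound 3 is estimated at 45000 nM (range 20000 nM to 100000 nM), most likely again reported only as a limit.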

Compound 3, half-maximal inhibitory concentration: >= 40000 nM
Compound 3 ended at the assay's limit; the forecaster's own chance of this, stated with the estimate: 85%; the middle value is on the limit's open side.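

Compound 2 and compound 3 yield no readable step for chloro in place of trifluoromethoxy, both resting at the same limit: the limit of >= 40000 nM in this assay, at which 3 of the 3 values shown sit.
On these data alone, how the three compounds truly rank in this assay stays open.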